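Cyano in Place of Carboxy: Expectation for Compound 4

The source may report more compounds than this note shows. Statements on the series, on what has been measured and on what is new or still open speak of the compounds shown alone.

compound 1 `C=C(CC)C(=O)c1ccc(OCC(=O)Nc2ccc(C(=O)O)c(O)c2)c(Cl)c1Cl` — > 25000 nM, a limit of the assay
compound 2 `C=C(CC)C(=O)c1ccc(OCC(=O)Nc2ccc(C(=O)O)cc2)c(Cl)c1Cl` — 5000 nM
compound 3 `C=C(CC)C(=O)c1ccc(OCC(=O)Nc2nc(/C(=N\OC)C(=O)O)cs2)c(Cl)c1Cl` — > 25000 nM, a limit of the assay

Within the data shown here, in a functional assay on CLL cells (Homo sapiens) for cytotoxicity, read by MTT assay, with a stated time of 48 h (a lower number here means that less compound is needed, a higher number that more compound is needed for the effect), compound 2 gives 5000 nM, the only plain number among the three compounds measured. Compound 1 and compound 3 each sit at the limit of > 25000 nM in this assay, at which 2 of the 3 values shown sit. Among the measured compounds shown here, the one measured step is an at least 5.0-fold lower number from compound 1 to compound 2 (0.69 log units; beyond the scatter), which concerns the hydroxy group and not the acid.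

Compound 4 `C=C(CC)C(=O)c1ccc(OCC(=O)Nc2ccc(C#N)cc2)c(Cl)c1Cl` is still to be measured in this assay. It differs from compound 2 in cyano in place of carboxy on an aromatic carbon. For the measured compounds named here, no measured pair shares this change, so the step from compound 1 to compound 2 gives only a sense of how far a single small change on that ring can move the number, and says nothing about the direction here. With the acid gone and a nitrile in its place, the outcome is open; a step of modest size in either direction, or none beyond the scatter, is equally plausible on these data.

The account therefore expects the number for compound 4 to stay near that of compound 2, with no change at the digits printed from compound 2 to compound 4 (within the scatter) as the expected step. Compound 4 is estimated at 5000 nM, within a range from 1200 nM to 25000 nM.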

Compound 4, half-maximal effective concentration: 7800 nM
Compound 4: middle estimate off by 1.6-fold (0.19 log units), on the low side; the range from low to high includes it.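

In this assay, among these compounds, the carboxy group on the aromatic carbon para to a large group is exchanged directly for the first time, and cyano in its place gives a 1.6-fold higher number from compound 2 to compound 4 (0.19 log units; within the scatter). The earlier step, an at least 5.0-fold lower number from compound 1 to compound 2 (0.69 log units; beyond the scatter), concerned a hydroxy group on the same ring and left the carboxy group untouched, so it could not show whether that group was needed. This pair shows that a number of this size does not depend on the carboxy group, since a cyano group, which carries no hydrogen-bond donor, serves equally well here in this assay.

As far as these compounds go, whether other groups at this position, such as a primary amide, a methyl ester or an amine, would also stay within the scatter remains open, as does whether the same exchange would hold on a different core, and one pair cannot say why the number holds. The rest of the set offers little help on these questions: the limit of > 25000 nM in this assay, at which 2 of the 4 values shown sit.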